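Swapping a bromophenyl for a methylphenyl on a thioether

The source may report more compounds than this note shows. Statements on the series, on what has been measured and on what is new or still open speak of the compounds shown alone.

Measured compounds:
Compound 1, `COc1cc(-c2nnc(SCc3ccc([N+](=O)[O-])cc3)o2)ccc1O`, 14200 nM
Compound 2, `COc1cc(-c2nnc(SCc3cccc(Br)c3)o2)ccc1O`, 48100 nM

Of the compounds shown here, two have been tested in a functional assay on cells (T-cell, Mus musculus, strain BALB/c) for inhibition, read by MTT assay, with stated times of 24 h and 72 h; on this read-out higher numbers stand for weaker inhibition and lower numbers for stronger inhibition. Compound 1 gives 14200 nM in this assay, and compound 2 gives 48100 nM. Of these two numbers, compound 2 stands at the higher one, and the gap to compound 1 is beyond the usual scatter, so compound 2 is the weaker inhibitor of the pair.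

Compound 3, `COc1cc(-c2nnc(SCc3ccc(C)cc3)o2)ccc1O`, has not yet been measured. It differs from compound 2 in one place: 4-methylphenyl in place of 3-bromophenyl on a saturated chain carbon bound to a sulfur. Among the compounds with values here, no step between two measured compounds reports what this kind of exchange does, so only a cautious expectation is possible.

Compound 3 is expected to land near the measured pair, with the step of a 1.6-fold lower number from compound 2 to compound 3 (0.21 log units; within the scatter) being small and possibly not beyond the scatter. Compound 3 is therefore estimated at 30000 nM, with a range from 8000 nM to 110000 nM.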

Compound 3, half-maximal inhibitory concentration: 6210 nM
Beside the measured number, compound 3's estimate is 4.8-fold (0.68 log units) above it; the measured number lies below the stated range.
By their numbers in this assay, from the lowest: compound 3; then compound 1; then compound 2.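

In this assay the group on the saturated chain carbon bound to a sulfur clearly matters: 4-methylphenyl in place of 3-bromophenyl gives a 7.7-fold lower number from compound 2 to compound 3 (0.89 log units; beyond the scatter) and so strengthens inhibition. Methyl in place of nitro on an aromatic carbon also gives a step beyond the scatter, a 2.3-fold lower number from compound 1 to compound 3 (0.36 log units; beyond the scatter), which makes compound 3 the strongest inhibitor of the three. Nothing shown here explains why these exchanges change the number.

The names 3-bromophenyl and 4-methylphenyl differ in both the substituent and its number on the ring, so the compounds shown cannot separate the effect of methyl for bromine from the effect of where the group sits. From the compounds shown here alone, how an amine or a carboxylic acid on this ring would behave also stays open.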